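The source may hold more compounds than are shown below. What is called first, only, known or untested is meant among the compounds shown, and "the series" means these compounds.

Measured in a functional assay on HEK293 cells (Homo sapiens) for cytotoxicity; a higher number here means that more compound is tolerated, a lower number that less compound is tolerated:
- compound 1 `COc1ccc([C@H]2CC(=O)N(c3cccc(C#N)c3)C2)cc1OC1CCCC1`: > 10000 nM
- compound 2 `COc1ccc([C@H]2CC(=O)N(c3cccc(NCCCc4ccccc4)c3)C2)cc1OC1CCCC1`: > 10000 nM
- compound 3 `COc1ccc([C@H]2CC(=O)N(c3cccc(NS(=O)(=O)c4ccccc4Br)c3)C2)cc1OC1CCCC1`: > 10000 nM

Compound 3 stands at > 10000 nM, which is a limit of the assay and not a number. The other values are of the same kind: the limit of > 10000 nM in this assay, at which 3 of the 3 values shown sit.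

In compound 4 `COc1ccc([C@H]2CC(=O)N(c3cccc(NS(=O)(=O)c4cccc(Br)c4)c3)C2)cc1OC1CCCC1`, 3-bromophenyl stands in place of 2-bromophenyl on a sulfonyl sulfur: 3-bromophenyl in place of 2-bromophenyl on a sulfonyl sulfur. The two compounds have the same atoms, joined differently.

The measured steps closest to this change are a step that the two limits leave unreadable from compound 2 to compound 3 and a step that the two limits leave unreadable from compound 1 to compound 3. Neither compares these two bromophenyl groups, and neither has a size that can be read. For the measured compounds named here, the only guide is that all three compounds, with quite different groups on the shared core, sit at the same limit.

No change beyond the usual scatter is expected in this assay, in either direction, and the expected step is a number no higher from compound 3 to compound 4 (the limit leaves the size open). For compound 4 the estimated value is 10000 nM, with an expected range from 5000 nM to 30000 nM, and the assay will probably report only a limit again.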

Compound 4, half-maximal cytotoxic concentration: > 10000 nM
Compound 4: a limit, no number (the forecaster's own chance of this, stated with the estimate: 85%); the middle value sits exactly at the limit.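

Compound 4 gives > 10000 nM in this assay, which is a limit of the assay and not a number. No step between compound 4 and compound 1, compound 2 or compound 3 can be read, as all share one limit: the limit of > 10000 nM in this assay, at which 4 of the 4 values shown sit.

Going by these compounds, what stays open is the actual tolerated concentration of each of the four compounds in this assay, and whether 2-bromophenyl and 3-bromophenyl differ there at all.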